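The compounds below may be only part of what the source reports. "The series", "measured", "known", "first", "only" and "open" are said of these compounds alone.

Measured in a functional assay on K562 cells (Homo sapiens) for cytotoxicity, read by MTT assay, with a stated time of 24 h; a lower number here means a stronger inhibitor, a higher number a weaker inhibitor:
- compound 1 `C=C1CC[C@H]2C(C)(C)CCC[C@]2(C)[C@H]1CCC(C)CC(=O)O`: > 200000 nM
- compound 2 `C=C1CC[C@H]2C(C)(C)CCC[C@]2(C)[C@H]1CCC(C)CC(=O)OC`: > 200000 nM
- compound 3 `COc1ccc(/C=C2\CC[C@H]3C(C)(C)CCC[C@]3(C)[C@H]2CCC(C)CC(=O)O)cc1OC`: > 200000 nM

Each of these values is a limit of the assay, so compound 3 has no number, only this limit. Compound 4 `CC(CC[C@H]1/C(=C/c2ccc(I)cc2)CC[C@H]2C(C)(C)CCC[C@]12C)CC(=O)O` carries 4-iodophenyl in place of 3,4-dimethoxyphenyl on a double-bonded chain carbon bound to a double-bonded ring carbon.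

Within the data shown here, the one measured step, a step that the two limits leave unreadable from compound 1 to compound 2, concerns methyl in place of hydrogen on an oxygen next to a carbonyl group, and gives no size to carry over. The series offers only (the limit of > 200000 nM in this assay, at which 3 of the 3 values shown sit). No clear direction is therefore expected in this assay, and compound 4 is expected to stay near that limit. The expected step is a number no higher from compound 3 to compound 4 (the limit leaves the size open). For compound 4 the estimated value is 200000 nM, with an expected range of 70000 nM to 400000 nM.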

Compound 4, half-maximal inhibitory concentration: 98000 nM
Compound 4: the middle estimate sits 2.0-fold (0.31 log units) above what was measured; low and high end bracket the measured number.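

In this assay, among these compounds, compound 4, with 4-iodophenyl in place of 3,4-dimethoxyphenyl on a double-bonded chain carbon bound to a double-bonded ring carbon, gives the only value that is a number and not a limit. The change is an at least 2.0-fold lower number from compound 3 to compound 4 (0.30 log units; that floor lies within the scatter), so only a floor on its size is known, and that floor does not clear the usual scatter. The rest of the series gives no number to set beside it: the limit of > 200000 nM in this assay, at which 3 of the 4 values shown sit.

Going by these compounds, whether iodine itself matters at this place remains open, since neither an unsubstituted phenyl nor a 4-bromophenyl stands beside compound 4. Also open, on these data alone, is how a primary amide in place of the carboxylic acid would read with the 4-iodophenyl group present.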